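Aryl return at the saturated ring carbon of compound 3

This account rests on a few compounds, and the source may have more. Where it says the series, first, only, none or still open, it means among the compounds named here.

Working notes on a small pyrazoline series carrying a 4-sulfamoylphenyl on ring nitrogen and a 5-chloro-2-hydroxy-4-methylphenyl on the shared core, varied at the saturated ring carbon. Compound 1 `Cc1cc(O)c(C2=NN(c3ccc(S(N)(=O)=O)cc3)C(c3ccccc3O)C2)cc1Cl` gives 27200 nM in a functional assay on SK-MEL-2 cells (Homo sapiens) for antiproliferative activity, with a stated time of 48 h; on this read-out higher numbers stand for weaker inhibition of growth and lower numbers for stronger inhibition of growth. Compound 2 `Cc1cc(O)c(C2=NN(c3ccc(S(N)(=O)=O)cc3)C(c3ccccc3Cl)C2)cc1Cl` gives 31000 nM; the step of a 1.1-fold higher number from compound 1 to compound 2 (0.06 log units; within the scatter) is within the scatter. Compound 3 `Cc1cc(O)c(C2=NN(c3ccc(S(N)(=O)=O)cc3)C(/C=C/c3ccccc3)C2)cc1Cl` gives 58200 nM, the highest of the three numbers; the step of a 2.1-fold higher number from compound 1 to compound 3 (0.33 log units; beyond the scatter) is beyond the scatter, while a 1.9-fold higher number from compound 2 to compound 3 (0.27 log units; within the scatter) is within it.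

Compound 4 `COc1ccc(C2CC(c3cc(Cl)c(C)cc3O)=NN2c2ccc(S(N)(=O)=O)cc2)cc1OC` has not been measured. Its change from compound 3 is 3,4-dimethoxyphenyl in place of 2-phenylethenyl on a saturated ring carbon. The two steps that bear on it run the other way: replacing an aryl ring at this carbon by 2-phenylethenyl gave a 2.1-fold higher number from compound 1 to compound 3 (0.33 log units; beyond the scatter) and a 1.9-fold higher number from compound 2 to compound 3 (0.27 log units; within the scatter). Putting an aryl ring back is therefore expected to roughly reverse that, a modest downward step, of about the size of a 1.9-fold lower number from compound 3 to compound 4 (0.29 log units; within the scatter). Whether the two methoxy groups shift the number beyond what the 2-hydroxyphenyl or 2-chlorophenyl gave cannot be told from the data. Compound 4 is expected to give 30000 nM, with a range from 14000 nM to 65000 nM.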

Compound 4, concentration for total growth inhibition: 32700 nM
Compound 4: middle estimate off by 1.1-fold (0.04 log units), on the low side, within the range that was stated.
By their numbers in this assay, from the lowest: compounds 1, 2, 4 and 3 (each within the scatter of the next, the first and the last beyond it).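

In this assay, 3,4-dimethoxyphenyl on the saturated ring carbon cannot be told apart from either aryl group seen earlier (a 1.2-fold higher number from compound 1 to compound 4 (0.08 log units; within the scatter); a 1.1-fold higher number from compound 2 to compound 4 (0.02 log units; within the scatter)), so three differently substituted aryl rings at this carbon now give values within the scatter of one another, even though the entering group brings 2 hydrogen-bond acceptors. The change from 2-phenylethenyl to 3,4-dimethoxyphenyl also stays within the scatter (a 1.8-fold lower number from compound 3 to compound 4 (0.25 log units; within the scatter)), which means that compound 4 adds no second gap beyond the scatter between an aryl ring and 2-phenylethenyl, and the only such gap remains the earlier one (a 2.1-fold higher number from compound 1 to compound 3 (0.33 log units; beyond the scatter)). Nothing available bears on why the values fall as they do.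

On these data alone, whether an amine, a carboxylic acid or a longer saturated alkyl chain on this carbon would give a value outside the narrow spread of these four compounds remains open. All four also carry the same 4-sulfamoylphenyl and 5-chloro-2-hydroxy-4-methylphenyl groups, so how changes to either group would read in this assay is open as well.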